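The source may report more compounds than this note shows. Statements on the series, on what has been measured and on what is new or still open speak of the compounds shown alone.

Compound 1 `O=c1oc2c(O)c(O)ccc2cc1-c1cccs1` gives 4830 nM in an assay on CHO cells for displacement of a labelled ligand from transmembrane domain-containing protein TMIGD3 (Homo sapiens); on this read-out lower numbers stand for stronger inhibition and higher numbers for weaker inhibition.
Compound 2 `O=c1oc2c(O)cccc2cc1-c1ccsc1` gives 2870 nM in this assay.

Of these two numbers compound 2 has the lower one, but its gap to compound 1 lies within the usual scatter, so the two cannot be told apart. Compound 3 `O=c1oc2c(O)c(O)ccc2cc1-c1ccsc1` has not yet been measured in this assay. It differs from compound 2 by hydroxy in place of hydrogen on an aromatic carbon. Within the data shown here, no single step of this kind has been measured, so only a small change is expected in this assay, in no clear direction beyond the scatter. The estimate for compound 3 is 3500 nM, between 1200 nM and 10000 nM. This is an expected step of a 1.2-fold higher number from compound 2 to compound 3 (0.09 log units; within the scatter).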

Compound 3, inhibition constant: 5310 nM
Compound 3: the middle estimate sits 1.5-fold (0.18 log units) below what was measured; measured number inside the range.
By their numbers in this assay, from the lowest: compounds 2, 1 and 3 (each within the scatter of the next).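

Hydroxy in place of hydrogen, on the aromatic carbon ortho to a hydroxy group, gives a 1.9-fold higher number from compound 2 to compound 3 (0.27 log units; within the scatter) in this assay. Thiophen-3-yl in place of thiophen-2-yl gives a 1.1-fold higher number from compound 1 to compound 3 (0.04 log units; within the scatter), so neither change can be told from no change at all. No measurement shown here offers an explanation for these results. On these data alone, whether a methoxy group or an amine at this position would move the number beyond the scatter remains open.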